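A Bromo-Bearing Anilide Core Tested for Cytotoxicity

The compounds below may be only part of what the source reports. "The series", "measured", "known", "first", "only" and "open" are said of these compounds alone.

Compounds measured so far:
compound 1 `Nc1ccc(Nc2c(C(=O)NCc3ccc(F)cc3)nc(Br)c3cccnc23)cc1` — 10000 nM
compound 2 `N[C@H]1CC[C@H](Nc2c(C(=O)NCc3ccccn3)nc(Br)c3cccnc23)CC1` — "not determined" (no result reported)
compound 3 `C[C@H](CO)Nc1nc(C(=O)NCc2ccc(F)cc2)c(O)c2ncccc12` — "not determined" (no result reported)

Going by the values given here, in a functional assay on HCT-116 cells (Homo sapiens) for cytotoxicity, read by MTT assay, with a stated time of 72 h (on this read-out higher numbers stand for weaker inhibition and lower numbers for stronger inhibition), compound 1 gives 10000 nM, the only number in hand. In this assay compound 2 gives "not determined" (no result reported) and compound 3 gives "not determined" (no result reported), so neither carries a result. Compound 4 `C[C@H](Nc1c(C(=O)NCc2ccc(F)cc2)nc(Br)c2cccnc12)c1ccccc1` is the next to be tested. Its change from compound 1 is 1-phenylethyl in place of 4-aminophenyl on a nitrogen on an aromatic ring. Among the compounds with values here, no step between measured compounds exists here, so nothing in the data fixes the size of this move. Within the data shown here, on the single number for compound 1, the step from compound 1 to compound 4 is expected to be a 2.0-fold lower number from compound 1 to compound 4 (0.30 log units; within the scatter) in this assay, a modest gain toward stronger inhibition that may not exceed the scatter. Compound 4 is therefore expected to give about 5000 nM in this assay, within 1000 nM to 20000 nM.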

Compound 4, half-maximal inhibitory concentration: > 20000 nM
Compound 4 was reported as a limit; the forecaster's own chance of this, stated with the estimate: 30%; middle value at least 4.0-fold (0.60 log units) away from the limit.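

In this assay, this nitrogen on an aromatic ring now has its first readable step, as 1-phenylethyl in place of 4-aminophenyl gives an at least 2.0-fold higher number from compound 1 to compound 4 (0.30 log units; that floor lies within the scatter). The swap brought no gain toward stronger inhibition, though the printed floor does not establish a real loss. Compound 4 is reported only as a limit, not as a number: the limit of > 20000 nM in this assay, at which 1 of the 4 values shown sits.

As far as these compounds go, it remains open whether the amine of compound 1 matters, which a plain phenyl on this nitrogen would test. Also open, from the compounds shown here alone, is how a carboxylic acid on that ring would read.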